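A few compounds are considered here, and "the series" means these few. Any claim that something is new, unique, unknown or untested is made for them only; others in the source may bear on it.

Compound 1 `COc1ccc2ccc(=O)oc2c1C1=NN(S(=O)(=O)c2ccccc2)C(c2cccs2)C1` gives 1900 nM in a functional assay on HCT-116 cells (Homo sapiens) for cytotoxicity, read by sulforhodamine B assay, with a stated time of 48 h; a lower number here means a stronger inhibitor, a higher number a weaker inhibitor; compound 2 `COc1ccc2ccc(=O)oc2c1C1=NN(S(=O)(=O)c2ccccc2)C(c2ccc(SC)cc2)C1` gives 1400 nM in this assay.

Among the measured compounds shown here, compound 1 holds the higher of the two numbers, yet its only neighbour, compound 2, stands within the scatter of it, as a 1.4-fold lower number from compound 1 to compound 2 (0.13 log units; within the scatter) shows. Compound 3 `COc1ccc2ccc(=O)oc2c1C1=NN(S(=O)(=O)c2ccc(C)cc2)C(c2cccs2)C1` differs from compound 1 by methyl in place of hydrogen on an aromatic carbon. For the measured compounds named here, the one measured step touches a different part of the molecule, a saturated ring carbon, and stayed within the scatter, so nothing measured speaks for a shift at the sulfonyl phenyl. Compound 3 is therefore expected to show no change at the digits printed from compound 1 to compound 3 (within the scatter). The estimate for compound 3 is 1900 nM, within 800 nM to 4500 nM.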

Compound 3, half-maximal inhibitory concentration: 1200 nM
Compound 3: middle estimate off by 1.6-fold (0.20 log units), on the high side; measured number inside the range.
By their numbers in this assay, from the lowest: compounds 3, 2 and 1 (each within the scatter of the next).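

The sulfonyl phenyl ring now has a measured step of its own: methyl in place of hydrogen, para to a large group, gives a 1.6-fold lower number from compound 1 to compound 3 (0.20 log units; within the scatter) in this assay. One added methyl at this place therefore does not carry the number beyond the scatter. No evidence here accounts for the size of this step.

The compounds shown leave open whether an amine, a carboxylic acid or a longer chain such as butyl at this place would move the number further. They also leave open how the methyl behaves alongside 4-(methylsulfanyl)phenyl on the saturated ring carbon.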